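Replacing the Aryl Group on the Amide-Type Nitrogen

The source may hold more compounds than are shown below. What is called first, only, known or untested is meant among the compounds shown, and "the series" means these compounds.

Values in an assay on CHO cells for displacement of a labelled ligand from adenosine receptor A1 (Homo sapiens), tested at 10 uM; on this read-out higher numbers stand for more inhibition at the one concentration tested (going by the name of the read-out) and lower numbers for less inhibition:
compound 1 `O=C(Nc1nn(-c2ccccc2)c(=O)c2ccccc12)c1ccccc1`: 44%
compound 2 `COc1ccc(OC)c(NC(=O)Nc2nn(-c3ccccc3)c(=O)c3ccccc23)c1`: 0%
compound 3 `COc1ccccc1NC(=O)Nc1nn(-c2ccccc2)c(=O)c2ccccc12`: 0%

Compound 3 stands level with compound 2, the two together the lowest of the three numbers. Its nearest neighbour is compound 2, with no change at the digits printed from compound 2 to compound 3 (within the scatter). Its furthest is compound 1, with a number 44 percentage points lower from compound 1 to compound 3 (beyond the scatter). Compound 4 `Cc1ccc(NC(=O)Nc2nn(-c3ccccc3)c(=O)c3ccccc23)cc1` differs from compound 3 by 4-methylphenyl in place of 2-methoxyphenyl on an amide-type nitrogen. Going by the values given here, no measured step changes this aryl group in the same way: the step from compound 2 to compound 3 only removed one methoxy and left the number where it was, and the step from compound 1 to compound 3 changed the substituent on the carbonyl carbon altogether. Among the compounds with values here, both aryl-amino compounds measured so far gave no inhibition, so the step to compound 4 is expected to stay within the scatter, read as a number 8 percentage points higher from compound 3 to compound 4 (within the scatter). Compound 4 is therefore estimated at 8% in this assay, in a range from 0% to 30%.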

Compound 4, a percentage reported as inhibition, at one concentration (the size of the read-out at that concentration, not a potency): 29%
Compound 4: the middle estimate sits 21 percentage points below what was measured; measured number inside the range.
By their numbers in this assay, from the lowest: compounds 2 and 3 (each within the scatter of the next); then compound 4; then compound 1.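

The aryl group on the amide-type nitrogen is not silent in this assay: 4-methylphenyl in place of 2-methoxyphenyl gives a number 29 percentage points higher from compound 3 to compound 4 (beyond the scatter), and 4-methylphenyl in place of 2,5-dimethoxyphenyl gives a number 29 percentage points higher from compound 2 to compound 4 (beyond the scatter). The absence of inhibition seen with the two methoxy-bearing compounds therefore does not hold for every aryl-amino compound here, although the change on the carbonyl carbon still leaves a number 15 percentage points lower from compound 1 to compound 4 (beyond the scatter). Nothing available explains why this aryl change moves the number.

The compounds shown change the substituent and its name-given ring position together, so a 4-methoxyphenyl or 2-methylphenyl group would be needed to tell those two changes apart. As far as these compounds go, how a cyclohexyl group or a longer alkyl chain on this nitrogen would read also remains open.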